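The compounds below may be only part of what the source reports. "The series", "measured", "known", "first", "only" and "open" are said of these compounds alone.

Compound 1 `C[C@H](NC(=O)c1cccc(F)c1)c1ccc(NC(=O)N2CC(c3cccnc3)C2)cc1`: 11000 nM
Compound 2 `C[C@@H](c1ccc(NC(=O)N2CC(c3ccc(N)nc3)C2)cc1)N1Cc2ccccc2C1=O`: 220000 nM

In a physicochemical assay for solubility, read by LC-MS, in phosphate buffer, with a stated time of 24 h, at pH 6.8 (a lower number here means a less soluble compound, a higher number a more soluble compound), compound 2 gives 220000 nM, the higher of the two numbers, and compound 1 lies lower at 11000 nM, a gap beyond the scatter.

Compound 3 `C[C@H](NC(=O)c1cccc(F)c1)c1ccc(NC(=O)N2CC(c3ccc(N)nc3)C2)cc1` has not yet been measured. It departs from compound 2 in one place, on a saturated chain carbon bound to an aromatic carbon and a saturated chain carbon: a group of 10 heavy atoms (7 carbon, 1 nitrogen, 1 oxygen, 1 fluorine; one six-membered aromatic ring of carbon only) in place of a group of 10 heavy atoms (8 carbon, 1 nitrogen, 1 oxygen; one five-membered non-aromatic ring with 1 hetero atom, one six-membered aromatic ring of carbon only), on a saturated chain carbon bound to an aromatic carbon and a saturated chain carbon. The entering group, ((3-fluorophenyl)carbonyl)amino, also occurs in compound 1, though that compound differs from compound 3 elsewhere too. For the measured compounds named here, no measured pair shows this change alone, so any forecast is uncertain. Going by the values given here, the only measured compound with this group is compound 1, at 11000 nM, which points to a lower number. The expected change is a fall beyond the scatter, estimated as a 4.4-fold lower number from compound 2 to compound 3 (0.64 log units; beyond the scatter). Compound 3 is expected near 50000 nM, within an estimated range of 15000 nM to 170000 nM.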

Compound 3, solubility: 32000 nM
Compound 3: the middle estimate sits 1.6-fold (0.19 log units) above what was measured, within the range that was stated.
By their numbers in this assay, from the lowest: compound 1; then compound 3; then compound 2.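

Compounds 1 and 2 differ in two places, so their gap could not be assigned to either place. In this assay, ((3-fluorophenyl)carbonyl)amino in place of the group with the five-membered non-aromatic ring, on the saturated chain carbon, gives a 6.9-fold lower number from compound 2 to compound 3 (0.84 log units; beyond the scatter) and thus isolates that change, while amino in place of hydrogen on an aromatic carbon gives a 2.9-fold higher number from compound 1 to compound 3 (0.46 log units; beyond the scatter) and isolates the other. Each single change therefore moves the number beyond the scatter, and the step at the saturated chain carbon is the larger as printed, yet nothing measured here explains either step.

The compounds shown leave open whether the fluorine matters in the entering group, since no plain benzoylamino group appears for comparison. They also leave open how a methoxy group or a dimethylamino group would compare with amino on that aromatic carbon.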